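Aryl swap on the amide chain, compound 2 to compound 3

The source may report more compounds than this note shows. Statements on the series, on what has been measured and on what is new or still open speak of the compounds shown alone.

Among the compounds with values here, in a functional assay on A2780 cells (Homo sapiens) for antiproliferative activity, read by resazurin assay, with a stated time of 72 h (on this read-out lower numbers stand for stronger inhibition and higher numbers for weaker inhibition), compound 1 (`CN(Cc1ccccc1F)C(=O)c1cc2c(Cc3ccccc3)n[nH]c2cc1O`) gives 1500 nM as the only number so far. Within the data shown here, compound 2 (`CN(Cc1cccc(C(F)(F)F)c1)C(=O)c1cc2c(Cc3ccccc3)n[nH]c2cc1O`) has no number to stand on: its entry reads "not determined" (no result reported) and no measured step starts from it. Compound 3 (`CCc1ccc(CN(C)C(=O)c2cc3c(Cc4ccccc4)n[nH]c3cc2O)cc1`) carries the shared core and is still unmeasured. Its structural change from compound 2 is 4-ethylphenyl in place of 3-(trifluoromethyl)phenyl on a saturated chain carbon bound to an amide-type nitrogen with 4-ethylphenyl in place of 3-(trifluoromethyl)phenyl on a saturated chain carbon bound to an amide-type nitrogen. Among the measured compounds shown here, with no measured step available, no shift in either direction is expected in this assay from the level of compound 1, which gives 1500 nM. Compound 3 is estimated at 1500 nM with an expected range from 500 nM to 4500 nM in this read-out.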

Compound 3, half-maximal inhibitory concentration: 9400 nM
Compound 3: the middle estimate sits 6.3-fold (0.80 log units) below what was measured, outside the stated range (above it).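

In this assay, the aryl group on a saturated chain carbon bound to an amide-type nitrogen is shown to move the read-out: 4-ethylphenyl in place of 2-fluorophenyl gives a 6.3-fold higher number from compound 1 to compound 3 (0.80 log units; beyond the scatter) on the shared core. Within the data shown here, this is the first readable step and it runs toward weaker inhibition, so this position is not indifferent to the aryl group it carries. Nothing available on these compounds accounts for the shift.

The step from compound 2 to compound 3 cannot be read, so the 3-(trifluoromethyl)phenyl group remains unplaced relative to either neighbour. The compounds shown also leave open how this position would respond to an aryl ring bearing an amine or a carboxylic acid, or to a longer chain in place of the single saturated carbon.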